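Amide aryl variation on the shared core: nitro analogue

The source may hold more compounds than are shown below. What is called first, only, known or untested is meant among the compounds shown, and "the series" means these compounds.

Three amides on the shared core have been measured. Compound 1 `O=C(Nc1cccc(-c2oc3cc(-c4ccc(F)cc4)ccc3c(=O)c2O)c1)c1ccccc1F` gives 7240 nM in a functional assay on MDA-MB-231 cells (Homo sapiens) for antiproliferative activity, read by CCK-8 assay, with a stated time of 72 h; on this read-out higher numbers stand for weaker inhibition and lower numbers for stronger inhibition. Compound 2 `COc1ccc(C(=O)Nc2cccc(-c3oc4cc(-c5ccc(F)cc5)ccc4c(=O)c3O)c2)cc1` gives 16500 nM in this assay, and compound 3 `Cc1cc(C(=O)Nc2cccc(-c3oc4cc(-c5ccc(F)cc5)ccc4c(=O)c3O)c2)ccc1F` gives 7440 nM in this assay. Compound 3 holds the second highest of the three numbers; against compound 1 the gap is a 1.0-fold higher number from compound 1 to compound 3 (0.01 log units; within the scatter), while a 2.2-fold lower number from compound 2 to compound 3 (0.35 log units; beyond the scatter). Compound 4 `O=C(Nc1cccc(-c2oc3cc(-c4ccc(F)cc4)ccc3c(=O)c2O)c1)c1ccc([N+](=O)[O-])cc1` carries 4-nitrophenyl in place of 4-fluoro-3-methylphenyl on a carbonyl carbon. Among the compounds with values here, no measured step introduces a 4-nitrophenyl; the nearest comparisons are a 2.3-fold higher number from compound 1 to compound 2 (0.36 log units; beyond the scatter) and a 2.2-fold lower number from compound 2 to compound 3 (0.35 log units; beyond the scatter), both modest. A shift of similar size is therefore expected in this assay, most likely towards a higher number. For compound 4 the estimated step is a 1.4-fold higher number from compound 3 to compound 4 (0.15 log units; within the scatter). Compound 4 is expected to give about 10500 nM in this assay, within 4000 nM to 27000 nM.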

Compound 4, half-maximal inhibitory concentration: 14700 nM
Compound 4: the middle estimate sits 1.4-fold (0.15 log units) below what was measured; the measured number falls inside the stated range.
By their numbers in this assay, from the lowest: compounds 1, 3, 4 and 2 (each within the scatter of the next, the first and the last beyond it).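

In this assay, a fourth aryl group on this carbonyl carbon still gives no clear separation from the 4-fluoro-3-methylphenyl amide (a 2.0-fold higher number from compound 3 to compound 4 (0.30 log units; within the scatter)). Nitro in place of methoxy on an aromatic carbon also leaves the number unresolved (a 1.1-fold lower number from compound 2 to compound 4 (0.05 log units; within the scatter)), so among these para-free comparisons only the change from 2-fluorophenyl clears the scatter, and modestly (a 2.0-fold higher number from compound 1 to compound 4 (0.31 log units; beyond the scatter)). No measured evidence bears on the origin of these steps. As far as these compounds go, whether an amine or a carboxylic acid on this aryl ring would move the number remains open, as does the effect of a longer chain.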